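The source may hold more compounds than are shown below. What is called first, only, known or untested is meant among the compounds shown, and "the series" means these compounds.

The measured compounds in an assay on isolated protein for inhibition of Thymidylate synthase (Homo sapiens); on this read-out lower numbers stand for stronger inhibition and higher numbers for weaker inhibition:

compound 1 `Cc1ccc(-c2csc(=N)n2CC(=O)N2CCN(c3ccccc3)CC2)cc1` gives 5600 nM
compound 2 `Cc1ccc(-c2csc(=N)n2CC(=O)N2CCN(C)CC2)cc1` gives 19300 nM
compound 3 `CC(=O)N1CCN(C(=O)Cn2c(-c3ccc(C)cc3)csc2=N)CC1` gives 3650 nM

All three share one core and differ only in the group on an amine nitrogen in a ring. Among them compound 3 has the lowest number in this assay, but its nearest neighbour is compound 1, and the step of a 1.5-fold lower number from compound 1 to compound 3 (0.19 log units; within the scatter) lies within the scatter, so the two cannot be ranked against each other. Compound 2 stands apart: the step of a 5.3-fold lower number from compound 2 to compound 3 (0.72 log units; beyond the scatter) and the step of a 3.4-fold higher number from compound 1 to compound 2 (0.54 log units; beyond the scatter) are both beyond the scatter.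

Compound 4 `CC(=O)N1CCN(C(=O)Cn2c(-c3ccc(Cl)cc3)csc2=N)CC1` keeps the acetyl group of compound 3 and alters the other end of the molecule: chloro in place of methyl on an aromatic carbon, that is, 4-methylphenyl to 4-chlorophenyl. For the measured compounds named here, no measured step touches this part of the structure; every step so far concerns the group on the amine nitrogen in the ring. There is therefore nothing in the data that points to a direction for this change, and a step within the scatter is the plain expectation. Compound 4 is estimated to give 3500 nM in this assay, with a range from 1200 nM to 10000 nM, corresponding to an expected step of a 1.0-fold lower number from compound 3 to compound 4 (0.02 log units; within the scatter).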

Compound 4, inhibition constant: 11300 nM
Beside the measured number, compound 4's estimate is 3.2-fold (0.51 log units) below it, and the stated range ends below it.
By their numbers in this assay, from the lowest: compounds 3, 1, 4 and 2 (each within the scatter of the next, the first and the last beyond it).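

In this assay, for the compounds shown here, the step of a 3.1-fold higher number from compound 3 to compound 4 (0.49 log units; beyond the scatter) is the first measured change at this end of the molecule, and with the acetyl group held fixed it shows that this position is not silent. Chloro in place of methyl on an aromatic carbon, para to a large group, exchanges one heavy atom for one heavy atom, with no ring, hydrogen-bond donor, hydrogen-bond acceptor or net charge on either side, and that swap alone moves the number beyond the scatter, in the direction of weaker inhibition. No measured property is at hand that bears on this step, and the data give no explanation for it.

The compounds shown leave open whether chloro in place of methyl gives a step of similar size and direction when the amine nitrogen in the ring carries phenyl or methyl instead of acetyl. They also leave open how this position responds to other groups, such as fluoro, methoxy, an amine or a carboxylic acid, and whether the step seen here is specific to chloro.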